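The source may report more compounds than this note shows. Statements on the series, on what has been measured and on what is new or still open speak of the compounds shown alone.

Among the measured compounds shown here, in a functional assay on Calu-1 cells (Homo sapiens) for cytotoxicity, read by resazurin assay, with a stated time of 72 h (a lower number here means a stronger inhibitor, a higher number a weaker inhibitor), compound 2 `COc1cc(/C=C/C(=O)OCCCCCO[N+](=O)[O-])ccc1O` gives 26300 nM, the only exact number so far. Compound 3 `COc1cc(/C=C/C(=O)OCCCCCO[N+](=O)[O-])ccc1OCCCCCO[N+](=O)[O-]` differs from it by 5-(nitrooxy)pentyl in place of hydrogen on an oxygen on an aromatic ring, so the hydroxy becomes (5-(nitrooxy)pentyl)oxy. Compound 1 `O=C(/C=C/c1ccc(OCCCCCO[N+](=O)[O-])c(O)c1)OCCCCCO[N+](=O)[O-]` also has 5-(nitrooxy)pentyl on such an oxygen, and its result of > 50000 nM is only a limit of this assay. On that basis, a modest move towards weaker inhibition is expected, a 1.6-fold higher number from compound 2 to compound 3 (0.20 log units; within the scatter). The estimated value for compound 3 is 42000 nM, with an expected range from 18000 nM to 100000 nM.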

Compound 3, half-maximal inhibitory concentration: > 50000 nM
Compound 3 ended at the assay's limit; the forecaster's own chance of this, stated with the estimate: 45%; middle value at least 1.1-fold (0.07 log units) away from the limit.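

In this assay the change to 5-(nitrooxy)pentyl on this oxygen gives an at least 1.9-fold higher number from compound 2 to compound 3 (0.27 log units; that floor lies within the scatter) and brings no gain in inhibition, though that floor alone does not separate the two compounds. Compound 1 and compound 3 both end in limits, so the step between them cannot be read. Only a floor can be given for the change because the result of compound 3 is a limit, not a number: the limit of > 50000 nM in this assay, at which 2 of the 3 values shown sit.

Still open, on these data alone, is whether a shorter chain, an amine or a carboxylic acid on this oxygen would give a measurable value.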